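The source may report more compounds than this note shows. Statements on the series, on what has been measured and on what is new or still open speak of the compounds shown alone.

In an ADME assay on BHK-21 cells (Mesocricetus auratus) for cytotoxicity, read by MTT assay, with a stated time of 72 h (a lower number here means that less compound is tolerated, a higher number that more compound is tolerated), compound 2 (`Brc1ccc(NCc2cn(-c3ccccc3)nc2-c2ccccc2)cc1`) has no exact number, only a limit: compound 2 gives > 100000 nM. Compound 3 (`Cc1ccc(-c2nn(-c3ccccc3)cc2CNc2ccc(Br)cc2)cc1`) is also reported only as a limit, with compound 3 at > 100000 nM. Both sit at the limit of > 100000 nM in this assay, at which 2 of the 3 values shown sit. Within the data shown here, the only measured step is a step that the two limits leave unreadable from compound 2 to compound 3, so it offers no size to carry forward. Compound 1 (`FC(F)(F)c1ccc(-c2nn(-c3ccccc3)cc2CNc2ccc(Cl)cc2)cc1`), which also bears a trifluoromethyl, gives a true number of 31000 nM. Compound 4 (`FC(F)(F)c1ccc(NCc2cn(-c3ccccc3)nc2-c2ccccc2)cc1`) has trifluoromethyl in place of bromo on an aromatic carbon, para to a large group: trifluoromethyl in place of bromo on an aromatic carbon. Given compound 1 at 31000 nM, somewhat less tolerance is expected. The estimated change is an at least 1.6-fold lower number from compound 2 to compound 4 (0.22 log units; that floor lies within the scatter). For compound 4 the estimate is 60000 nM, expected to lie from 20000 nM to 150000 nM.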

Compound 4, half-maximal cytotoxic concentration: 37000 nM
Estimate against measurement, compound 4: 1.6-fold (0.21 log units) above, and the stated range covers the measured number.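

In this assay, among these compounds, trifluoromethyl in place of bromo on an aromatic carbon, para to a large group, gives the first readable step at this position: an at least 2.7-fold lower number from compound 2 to compound 4 (0.43 log units; beyond the scatter). The earlier step, which placed methyl on the other aromatic ring, cannot be read. The new step gives only a floor, not a full size, because compound 2 is reported only as a limit: the limit of > 100000 nM in this assay, at which 2 of the 4 values shown sit.

From the compounds shown here alone, the true size of this change remains open. So does how a nitrile or a carboxylic acid at this position would compare with trifluoromethyl.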